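Swapping a sulfur chain for a pyridine ring on the core

A few compounds are considered here, and "the series" means these few. Any claim that something is new, unique, unknown or untested is made for them only; others in the source may bear on it.

Of the compounds shown here, three share one core and have been measured in an assay on CHO cells for antagonist activity at transient receptor potential cation channel subfamily V member 1 (Homo sapiens), read by FLIPR; a higher number here means a weaker inhibitor, a lower number a stronger inhibitor. Compound 1 `CC(C(=O)NCc1ccc(C(F)(F)F)cc1N1CCCCCCC1)c1ccc(NS(C)(=O)=O)c(F)c1` gives 2.8 nM, compound 2 `CCCOc1cc(C(F)(F)F)ccc1CNC(=O)C(C)c1ccc(NS(C)(=O)=O)c(F)c1` gives 2 nM, and compound 3 `CC(C)CCSc1cc(C(F)(F)F)ccc1CNC(=O)C(C)c1ccc(NS(C)(=O)=O)c(F)c1` gives 1.4 nM. Compound 3 has the lowest of the three numbers, but its distances to the others are small: a 2.0-fold lower number from compound 1 to compound 3 (0.30 log units; within the scatter) and a 1.4-fold lower number from compound 2 to compound 3 (0.15 log units; within the scatter), so the three cannot be ranked against each other.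

Compound 4 `CC(C(=O)NCc1ccc(C(F)(F)F)cc1-c1cccnc1)c1ccc(NS(C)(=O)=O)c(F)c1` has not yet been measured in this assay. It differs from compound 3 in one place: pyridin-3-yl in place of isopentylsulfanyl on an aromatic carbon. The group that enters is an aromatic ring, whereas every group seen so far in that place has been an open chain or a saturated ring.

Among the compounds with values here, the steps that bear on this change are the two that alter the same place, a 2.0-fold lower number from compound 1 to compound 3 (0.30 log units; within the scatter) and a 1.4-fold lower number from compound 2 to compound 3 (0.15 log units; within the scatter), both within the scatter. None of them tests an aromatic group, so the comparison is indirect. Given that this place has tolerated three quite different groups without a shift beyond the scatter, the expected step is a 2.1-fold higher number from compound 3 to compound 4 (0.33 log units; beyond the scatter), no real change, with a wide uncertainty. For compound 4 the estimate in this assay is 3 nM, expected to lie between 1 nM and 12 nM.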

Compound 4, inhibition constant: 59.4 nM
Beside the measured number, compound 4's estimate is 20-fold (1.30 log units) below it; measured number above the stated range.
By their numbers in this assay, from the lowest: compounds 3, 2 and 1 (each within the scatter of the next); then compound 4.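

Within the data shown here, this position is less forgiving than the earlier compounds suggested: in this assay, the open chains and the eight-membered non-aromatic ring all lie within the scatter of one another, but pyridin-3-yl falls clearly outside that group. The change gives a 42-fold higher number from compound 3 to compound 4 (1.63 log units; beyond the scatter), and the other two comparisons agree, with a 30-fold higher number from compound 2 to compound 4 (1.47 log units; beyond the scatter) and a 21-fold higher number from compound 1 to compound 4 (1.33 log units; beyond the scatter). The data offer no measured explanation for this loss.

The size of the step is notable given that isopentylsulfanyl and pyridin-3-yl match in their counts of heavy atoms, hydrogen-bond donors and hydrogen-bond acceptors, and neither carries a net charge, so those counts do not separate the two groups. The compounds shown leave open whether the loss belongs to aromatic rings in general or to this pyridine ring with its nitrogen, a question that a plain phenyl ring, a pyridin-4-yl ring and a saturated cyclohexyl ring in the same place could help to separate.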